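The source may report more compounds than this note shows. Statements on the series, on what has been measured and on what is new or still open speak of the compounds shown alone.

Measured compounds:
compound 1 `CNc1cc(Oc2ccc(NC(=O)Nc3cccc(C(F)F)c3)cc2)ncn1` — 100 nM
compound 2 `Nc1cc(Oc2ccc(NC(=O)Nc3cccc(C(F)(F)F)c3)cc2)ncn1` — 25 nM
compound 3 `CNc1cc(Oc2ccc(NC(=O)Nc3cccc(C(C)(C)C)c3)cc2)ncn1` — 40 nM

In an assay on isolated protein for inhibition of serine/threonine-protein kinase TNNI3K (Homo sapiens) (on this read-out higher numbers stand for weaker inhibition and lower numbers for stronger inhibition), compound 2 shows the lowest number of the three, though compound 3 with 40 nM sits within the usual scatter of it, and only compound 1 with 100 nM stands clearly apart. Compound 4 `O=C(Nc1ccc(Oc2cc(NCCO)ncn2)cc1)Nc1cccc(C(F)(F)F)c1` arises from compound 2 by 2-hydroxyethyl in place of hydrogen on a nitrogen on an aromatic ring. Going by the values given here, the single measured step, a 2.5-fold lower number from compound 1 to compound 3 (0.40 log units; beyond the scatter), concerns a group on the aromatic carbon and not this nitrogen, so it bears on the new step only loosely. Among the compounds with values here, no measured pair adds a group to this nitrogen alone. Compound 4 is therefore expected to change little, a 1.4-fold higher number from compound 2 to compound 4 (0.15 log units; within the scatter), with an estimate of 35 nM and a range of 12 nM to 100 nM.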

Compound 4, half-maximal inhibitory concentration: 32 nM
Estimate against measurement, compound 4: 1.1-fold (0.04 log units) above; the measured number falls inside the stated range.
By their numbers in this assay, from the lowest: compounds 2, 4 and 3 (each within the scatter of the next); then compound 1.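

In this assay the nitrogen on the aromatic ring takes 2-hydroxyethyl in place of hydrogen with a 1.3-fold higher number from compound 2 to compound 4 (0.11 log units; within the scatter), so this added chain leaves the number within the scatter. Going by these compounds alone, the earlier compounds gave no step at this nitrogen, which makes this the first reading of the position. Nothing shown offers a reason for this result.

The compounds shown leave open how a plain ethyl group, a longer chain or a chain ending in a carboxylic acid would read on this nitrogen. Also open, as far as these compounds go, is whether the step would read the same with tert-butyl in place of trifluoromethyl.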